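Benzyl in place of cyclopentyl on the amine nitrogen

The source may report more compounds than this note shows. Statements on the series, on what has been measured and on what is new or still open speak of the compounds shown alone.

Compound 1 `CC(CNCC1CCCC1)Oc1cccc2ccc(N)nc12`: 100 nM
Compound 2 `CC(CNC1CC1)Oc1cccc2ccc(N)nc12`: 50 nM
Compound 3 `CC(CNC1CCCC1)Oc1cccc2ccc(N)nc12`: 30 nM

These three share one core and differ only in the group on the amine nitrogen, measured in an assay on cells with melanin-concentrating hormone receptor 1 (Homo sapiens) as the target, read by radioligand binding; a higher number here means a weaker inhibitor, a lower number a stronger inhibitor. Compound 3 has the lowest number; compound 2 lies within the scatter of it, while compound 1 lies beyond. Compound 4 `CC(CNCc1ccccc1)Oc1cccc2ccc(N)nc12` carries benzyl in place of cyclopentyl on an amine nitrogen. The step that bears most on this is a 3.3-fold lower number from compound 1 to compound 3 (0.52 log units; beyond the scatter), since cyclopentylmethyl, like benzyl, sets the ring one saturated carbon away from the nitrogen. The steps of a 2.0-fold lower number from compound 1 to compound 2 (0.30 log units; within the scatter) and a 1.7-fold lower number from compound 2 to compound 3 (0.22 log units; within the scatter) show that ring size alone changes little. Compound 4 is therefore expected to sit near compound 1, a step of a 2.3-fold higher number from compound 3 to compound 4 (0.37 log units; beyond the scatter). The estimate for compound 4 is 70 nM, within 30 nM to 160 nM.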

Compound 4, half-maximal inhibitory concentration: 100 nM
Beside the measured number, compound 4's estimate is 1.4-fold (0.15 log units) below it; low and high end bracket the measured number.
By their numbers in this assay, from the lowest: compounds 3, 2, 1 and 4 (each within the scatter of the next, the first and the last beyond it).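

On a saturated chain carbon bound to an amine nitrogen, phenyl in place of cyclopentyl leaves this assay unmoved (no change at the digits printed from compound 1 to compound 4 (within the scatter)), so here an aromatic ring and a saturated ring read alike. Benzyl on the amine nitrogen gives a weaker inhibitor than cyclopentyl (a 3.3-fold higher number from compound 3 to compound 4 (0.52 log units; beyond the scatter)), yet it stays within the scatter of cyclopropyl (a 2.0-fold higher number from compound 2 to compound 4 (0.30 log units; within the scatter)). No data shown give a reason for these numbers. Still open, going by these compounds, is how a fluorine or methoxy group on the benzyl ring, or a longer chain such as phenethyl, would read.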